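Adding a Nitro Group to a Second Core

The compounds below may be only part of what the source reports. "The series", "measured", "known", "first", "only" and "open" are said of these compounds alone.

Compound 1 `O=Cc1c(-c2ccccc2)nc2sc(Cc3ccc(Cl)cc3)nn12` carries a formyl group on its core. In a functional assay on HeLa cells (Homo sapiens) for cytotoxicity, with a stated time of 72 h (a lower number here means a stronger inhibitor, a higher number a weaker inhibitor), compound 1 gives 45000 nM. Compound 2 `O=Cc1c(-c2ccc([N+](=O)[O-])cc2)nc2sc(Cc3ccc(Cl)cc3)nn12` differs from compound 1 only by nitro in place of hydrogen on an aromatic carbon, and that change produced a 2.6-fold lower number from compound 1 to compound 2 (0.42 log units; beyond the scatter). Compound 3 `N#CSc1c(-c2ccccc2)nc2sc(Cc3ccc(Cl)cc3)nn12` has a different core group, the difference being (cyanosulfanyl in place of formyl on an aromatic carbon), and this gave a 3.8-fold lower number from compound 1 to compound 3 (0.57 log units; beyond the scatter). In this assay compound 3 gives 12000 nM, while compound 2 gives 17000 nM; these two numbers lie within the usual scatter of each other, so neither stands apart.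

Compound 4 `N#CSc1c(-c2ccc([N+](=O)[O-])cc2)nc2sc(Cc3ccc(Cl)cc3)nn12` has not yet been measured. Among the compounds with values here, it differs from compound 3 by nitro in place of hydrogen on an aromatic carbon, which is the same change, at a place described in the same words, as the one that led from compound 1 to compound 2. Within the data shown here, only one earlier example of this change exists, so the expectation rests on a single step. The step to compound 4 is expected to be a 2.4-fold lower number from compound 3 to compound 4 (0.38 log units; beyond the scatter), about as large as the earlier one because that change gave a 2.6-fold lower number from compound 1 to compound 2 (0.42 log units; beyond the scatter). In this assay compound 4 is therefore expected to give roughly 5000 nM, plausibly between 2000 nM and 14000 nM.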

Compound 4, half-maximal inhibitory concentration: 16000 nM
The estimate for compound 4 lay 3.2-fold (0.51 log units) below the measured number; the measured number lies above the stated range.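

Nitro in place of hydrogen did not carry over from the formyl core to the cyanosulfanyl core in this assay, where phenyl to 4-nitrophenyl gave a 1.3-fold higher number from compound 3 to compound 4 (0.12 log units; within the scatter), a step too small to read, and this differs from the earlier result: the same change on two cores in this assay, a 2.6-fold lower number (0.42 log units; beyond the scatter) from compound 1 to compound 2 and a 1.3-fold higher number (0.12 log units; within the scatter) from compound 3 to compound 4, 3.5-fold (0.55 log units) apart, beyond the scatter of two such steps.
The same holds when the pair is read the other way, since cyanosulfanyl in place of formyl gave a 1.1-fold lower number from compound 2 to compound 4 (0.03 log units; within the scatter) once the nitro group was present, which also differs from the earlier step: the same change on two cores in this assay, a 3.8-fold lower number (0.57 log units; beyond the scatter) from compound 1 to compound 3 and a 1.1-fold lower number (0.03 log units; within the scatter) from compound 2 to compound 4, 3.5-fold (0.55 log units) apart, beyond the scatter of two such steps.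
So in these four compounds, each change lowered the number when made alone from compound 1, but the two did not add up in compound 4; this does not show why, and one pair of cores gives no general rule for the series.

From the compounds shown here alone, it remains open whether an amine or a carboxylic acid in place of the nitro group would behave alike on both cores. Going by these compounds, it also remains open whether a longer chain on the core would change this picture.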